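Removing the N-methyl from the weakest sulfonamide

The source may report more compounds than this note shows. Statements on the series, on what has been measured and on what is new or still open speak of the compounds shown alone.

Compounds measured in a functional assay on BXPC-3 cells (Homo sapiens) for inhibition, read by MTT assay, with a stated time of 72 h; on this read-out higher numbers stand for weaker inhibition of growth and lower numbers for stronger inhibition of growth:
compound 1 `O=S(=O)(NCCCNCc1ccccc1Cl)c1cc(C(F)(F)F)cc(C(F)(F)F)c1`: 11000 nM
compound 2 `O=S(=O)(NCCCNCc1ccc(C(F)(F)F)cc1)c1cc(C(F)(F)F)cc(C(F)(F)F)c1`: 1700 nM
compound 3 `CN(CCCNS(=O)(=O)c1cc(C(F)(F)F)cc(C(F)(F)F)c1)Cc1ccccc1`: 39000 nM

Compound 3 gives the highest number of the three, standing at 39000 nM in this assay, with compound 1 nearest and compound 2 furthest away. The step from compound 3 to compound 4 `O=S(=O)(NCCCNCc1ccccc1)c1cc(C(F)(F)F)cc(C(F)(F)F)c1` is hydrogen in place of methyl on an amine nitrogen. The measured step that bears on it is a 3.5-fold higher number from compound 1 to compound 3 (0.55 log units; beyond the scatter), which also exchanged 2-chlorophenyl for phenyl, so the two changes are not cleanly separated; the step of a 6.5-fold lower number from compound 1 to compound 2 (0.81 log units; beyond the scatter) touches only the aryl group and is less informative here. Undoing the methyl alone should recover part of that difference, so a modest step downward is expected, a 2.6-fold lower number from compound 3 to compound 4 (0.41 log units; beyond the scatter). Compound 4 is therefore estimated at 15000 nM, within the range 5000 nM to 45000 nM.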

Compound 4, concentration for 50% growth inhibition: 13000 nM
Compound 4: middle estimate off by 1.2-fold (0.06 log units), on the high side; low and high end bracket the measured number.
By their numbers in this assay, from the lowest: compound 2; then compounds 1 and 4 (each within the scatter of the next); then compound 3.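

In this assay, going by these compounds alone, hydrogen in place of methyl on the amine nitrogen, with nothing else changed, gives a 3.0-fold lower number from compound 3 to compound 4 (0.48 log units; beyond the scatter) and so isolates the methyl step for the first time. Hydrogen in place of chloro gives a 1.2-fold higher number from compound 1 to compound 4 (0.07 log units; within the scatter) and stays within the scatter, so the gap between compound 1 and compound 3 follows the methyl rather than the chloro, while hydrogen in place of trifluoromethyl gives a 7.6-fold higher number from compound 2 to compound 4 (0.88 log units; beyond the scatter) and leaves compound 2 apart. Nothing available explains either step.

Going by these compounds, what an ethyl group on that nitrogen would do stays open, as does whether methyl costs the same with the 4-(trifluoromethyl)phenyl group of compound 2.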